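The source may report more compounds than this note shows. Statements on the series, on what has been measured and on what is new or still open speak of the compounds shown alone.

Measured compounds:
- Compound 1, `C=C(C)C(=O)N(Cc1ccc(OC)c(O)c1)c1cc(OC)c(OC)c(OC)c1`: 200 nM
- Compound 2, `CCC/C=C/C(=O)N(Cc1ccc(OC)c(O)c1)c1cc(OC)c(OC)c(OC)c1`: 95 nM
- Compound 3, `COc1ccc(CN(C(=O)CO)c2cc(OC)c(OC)c(OC)c2)cc1O`: 520 nM

All three share one core and differ only in the group on the carbonyl carbon of the amide. In a functional assay on HCT-116 cells (Homo sapiens) for inhibition, read by MTT assay, with a stated time of 48 h (a lower number here means a stronger inhibitor, a higher number a weaker inhibitor), compound 3 gives the highest number of the three, so it is the weakest inhibitor shown: compound 1 sits a 2.6-fold higher number from compound 1 to compound 3 (0.41 log units; beyond the scatter) and compound 2 sits a 5.5-fold higher number from compound 2 to compound 3 (0.74 log units; beyond the scatter).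

Compound 4, `CCC(=O)N(Cc1ccc(OC)c(O)c1)c1cc(OC)c(OC)c(OC)c1`, is not yet measured. It differs from compound 3 in one place: methyl in place of hydroxy on a saturated chain carbon bound to a carbonyl carbon. Among the measured compounds shown here, no measured step removes a hydroxy in this way, so the closest guidance is indirect. Both steps that lead into compound 3 end on the hydroxymethyl group and both raise the number, a 2.6-fold higher number from compound 1 to compound 3 (0.41 log units; beyond the scatter) and a 5.5-fold higher number from compound 2 to compound 3 (0.74 log units; beyond the scatter); leaving that group for ethyl may therefore be expected to move back toward the lower numbers of compound 1 and compound 2, though a short saturated chain need not behave like the longer unsaturated chain of compound 2. A modest step is expected, a 2.0-fold lower number from compound 3 to compound 4 (0.30 log units; within the scatter), so compound 4 is estimated at 260 nM, between 120 nM and 560 nM.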

Compound 4, half-maximal inhibitory concentration: 61 nM
Compound 4: middle estimate off by 4.3-fold (0.63 log units), on the high side; the measured number lies below the stated range.
By their numbers in this assay, from the lowest: compounds 4 and 2 (each within the scatter of the next); then compound 1; then compound 3.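

In this assay, exchanging one hydroxy for one methyl on a saturated chain carbon bound to a carbonyl carbon gives the largest step among these compounds (an 8.5-fold lower number from compound 3 to compound 4 (0.93 log units; beyond the scatter)), so a single heavy atom at this position can change the number substantially. The short ethyl group also does as well as the longer pent-1-en-1-yl, the two lying within the scatter (a 1.6-fold lower number from compound 2 to compound 4 (0.19 log units; within the scatter)), and it improves on 1-methylethenyl (a 3.3-fold lower number from compound 1 to compound 4 (0.52 log units; beyond the scatter)), so among these compounds neither extra chain length nor a double bond is needed for a low number. Nothing measured here explains these differences.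

On these data alone, it remains open whether an amine or a methoxy group on the same carbon would behave like the hydroxy or like the methyl. As far as these compounds go, how a longer saturated chain, such as butyl, would compare with ethyl also remains unknown.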